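Aryl group exchange from compound 2 to compound 3

A few compounds are considered here, and "the series" means these few. Any claim that something is new, unique, unknown or untested is made for them only; others in the source may bear on it.

Among the measured compounds shown here, in a functional assay on Jurkat cells (Homo sapiens) for inhibition, read by CCK-8 assay, with a stated time of 48 h (a lower number here means a stronger inhibitor of growth, a higher number a weaker inhibitor of growth), compound 1 `Cc1ccc(Nc2nc(Nc3ccc(N4CCN(C)CC4)cn3)ncc2Cl)cc1` gives 30900 nM and compound 2 `Cc1cc(C)c(Nc2nc(Nc3ccc(N4CCN(C)CC4)cn3)ncc2Cl)c(C)c1` gives 7600 nM, the lower of the two numbers measured so far. Compound 3 `COc1ccc(Nc2nc(Nc3ccc(N4CCN(C)CC4)cn3)ncc2Cl)cc1` is the next to be read, and the change is 4-methoxyphenyl in place of 2,4,6-trimethylphenyl on a nitrogen on an aromatic ring. For the measured compounds named here, only one measured step bears on it, a 4.1-fold lower number from compound 1 to compound 2 (0.61 log units; beyond the scatter), and it is modest. Going by the values given here, no measured compound yet carries 4-methoxyphenyl. By name, that group stands closer to the 4-methylphenyl of compound 1, at 30900 nM, than to the group of compound 2, so most of the measured step is expected to reverse. The expected step is a 2.9-fold higher number from compound 2 to compound 3 (0.46 log units; beyond the scatter), towards a higher number. For compound 3 the estimate is 22000 nM, with an expected range of 9000 nM to 50000 nM.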

Compound 3, concentration for 50% growth inhibition: 11200 nM
Estimate against measurement, compound 3: 2.0-fold (0.29 log units) above; the measured number falls inside the stated range.
By their numbers in this assay, from the lowest: compounds 2 and 3 (each within the scatter of the next); then compound 1.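

In this assay, 4-methoxyphenyl in place of 2,4,6-trimethylphenyl on the nitrogen gives a 1.5-fold higher number from compound 2 to compound 3 (0.17 log units; within the scatter) and so leaves the two aryl groups unresolved at this position. Methoxy in place of methyl on an aromatic carbon gives a 2.8-fold lower number from compound 1 to compound 3 (0.44 log units; beyond the scatter) in the same read-out, so a lower number than that of compound 1 does not depend on the 2,4,6-trimethylphenyl group: a change of one substituent on the 4-methylphenyl group also reaches it. No available data account for either step.

Still open, going by these compounds, is whether 2,4,6-trimethoxyphenyl, which carries methoxy on the pattern of compound 2, would move the number beyond the scatter of compound 2 and compound 3. Also open, on these data alone, is how this nitrogen substituent responds to an aryl group bearing an amine or a carboxylic acid.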